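The source may hold more compounds than are shown below. What is called first, only, known or untested is meant among the compounds shown, and "the series" means these compounds.

Measured compounds:

Compound 1, `CC[C@@H](C)[C@H](NC(=O)c1ccc(C(CC)(CC)c2ccc(OCC(=O)C(C)(C)C)c(C)c2)n1CC)C(=O)OC`: 590 nM
Compound 2, `CCN(CC)CCCNC(=O)c1ccc(C(CC)(CC)c2ccc(OCC(=O)C(C)(C)C)c(C)c2)n1CC`: 22 nM
Compound 3, `C=CCN(C)C(=O)c1ccc(C(CC)(CC)c2ccc(OCC(=O)C(C)(C)C)c(C)c2)n1CC`: 21600 nM

All three were tested in an assay on HL-60 cells for agonist activity at vitamin D3 receptor (Homo sapiens), read by microscopy, with a stated time of 96 h; on this read-out higher numbers stand for an effect only at larger amounts of compound and lower numbers for an effect already at smaller amounts. Compound 2 gives the lowest number of the three: compound 1 stands at a 27-fold lower number from compound 1 to compound 2 (1.43 log units; beyond the scatter) and compound 3 is the furthest away, at a 980-fold higher number from compound 2 to compound 3 (2.99 log units; beyond the scatter). Compound 4, `CCOC(=O)CC(C)OC(=O)c1ccc(C(CC)(CC)c2ccc(OCC(=O)C(C)(C)C)c(C)c2)n1CC`, has not yet been measured. It differs from compound 2 at the carbonyl carbon: a group of 9 heavy atoms (6 carbon, 3 oxygen; no ring) in place of a group of 9 heavy atoms (7 carbon, 2 nitrogen; no ring), on a carbonyl carbon.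

Among the compounds with values here, two measured steps bear on this change. Both replace the (3-(diethylamino)propyl)amino group of compound 2 with something lacking a nitrogen chain, and both go the wrong way: a 980-fold higher number from compound 2 to compound 3 (2.99 log units; beyond the scatter), and the tertiary amide of compound 3 also sits at a 37-fold higher number from compound 1 to compound 3 (1.56 log units; beyond the scatter). Compound 4 keeps an ester, as compound 1 does, but loses the amide nitrogen entirely, like compound 3. The expectation is therefore a large upward step, a 140-fold higher number from compound 2 to compound 4 (2.13 log units; beyond the scatter), landing between the numbers for compound 1 and compound 3. The estimate for compound 4 is 3000 nM, with a range from 300 nM to 30000 nM.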

Compound 4, half-maximal effective concentration: > 50000 nM
Compound 4 ended at the assay's limit (the forecaster's own chance of this, stated with the estimate: 10%); at least 16-fold (1.22 log units) between middle value and limit.
By their numbers in this assay, from the lowest: compound 2; then compound 1; then compound 3. At a limit, above all of these: compound 4.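

In this assay compound 4 gives > 50000 nM, which is a limit of the assay and not a number. All three earlier compounds keep a nitrogen on this carbonyl carbon, and compound 4, the only one with an oxygen there, lies furthest up: an at least 2200-fold higher number from compound 2 to compound 4 (3.35 log units; beyond the scatter), an at least 84-fold higher number from compound 1 to compound 4 (1.92 log units; beyond the scatter) and an at least 2.3-fold higher number from compound 3 to compound 4 (0.36 log units; beyond the scatter). Both groups in the change from compound 2 count 9 heavy atoms, so a chain of that size on this carbonyl carbon does not by itself keep the low number of compound 2.

Compound 4 loses the amide hydrogen and the diethylamino end together, so the two changes cannot be told apart here. The compounds shown leave open how a 3-(diethylamino)propyl ester would read, or an amide whose chain ends in a carboxylic acid.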